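Chain shortening in the triazole series: compound 2 to compound 3

The source may report more compounds than this note shows. Statements on the series, on what has been measured and on what is new or still open speak of the compounds shown alone.

Compound 1 `CCCCCCCc1cn(C(c2ccccc2)c2cc3cc(Br)ccc3nc2OC)nn1` gives 4.42% in an ADME assay on PC-3 cells (Homo sapiens) for cytotoxicity, read by sulforhodamine B assay, with a stated time of 48 h, tested at 10 uM; a higher number here means more inhibition at the concentration tested (going by the name of the read-out), a lower number less inhibition. Compound 2 `CCCCCc1cn(C(c2ccccc2)c2cc3cc(Br)ccc3nc2OC)nn1` gives 11.4% in the same assay. The step of a number 7 percentage points higher from compound 1 to compound 2 (within the scatter) is the only one measured so far, and it is within the scatter, so the two numbers of compound 1 and compound 2 cannot be ordered; compound 2 simply stands beside compound 1 among the two values at hand.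

Compound 3 `CCCc1cn(C(c2ccccc2)c2cc3cc(Br)ccc3nc2OC)nn1` is not yet measured. It differs from compound 2 by hydrogen in place of ethyl on a saturated chain carbon, three bonds along the chain from an aromatic carbon. For the measured compounds named here, the one measured step that bears on this is a number 7 percentage points higher from compound 1 to compound 2 (within the scatter), a cut of the same kind further out on the chain, and it stayed within the scatter. On that basis no step beyond the scatter is expected in this assay from compound 2 to compound 3, and the expected step is a number 1.4 percentage points lower from compound 2 to compound 3 (within the scatter). Compound 3 is therefore estimated at 10%, with a range from -5% to 25%.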

Compound 3, a percentage reported as inhibition, at one concentration (the size of the read-out at that concentration, not a potency): 8.3%
Estimate against measurement, compound 3: 1.7 percentage points above; the measured number falls inside the stated range.
By their numbers in this assay, from the lowest: compounds 1, 3 and 2 (each within the scatter of the next).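

Cutting the chain at the place three bonds along from an aromatic carbon extends the picture closer to the core: in this assay hydrogen in place of ethyl gives a number 3.1 percentage points lower from compound 2 to compound 3 (within the scatter) and hydrogen in place of butyl gives a number 3.9 percentage points higher from compound 1 to compound 3 (within the scatter). With these steps, all three compounds are within the scatter of one another, so no chain among them can be separated from the others, even across the largest cut shown. Nothing on hand explains these numbers or bears on them.

From the compounds shown here alone, whether any group at this position can move the read-out beyond the scatter remains open, for instance an amine or a carboxylic acid at the end of the chain. A methyl group or a chain longer than that of compound 1 is equally untested here.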